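Swapping a methylphenyl for a fluorophenyl on the shared core

The source may hold more compounds than are shown below. What is called first, only, known or untested is meant among the compounds shown, and "the series" means these compounds.

Compound 1, `Cc1ccc(NC2=CC(=O)c3c(nc4n3[C@H]3OC[C@@H](O)[C@H]3OC4)C2=O)cc1`, carries a (4-methylphenyl)amino group on the shared core. In a functional assay on MCF7 cells (Homo sapiens) for inhibition, read by sulforhodamine B assay (on this read-out lower numbers stand for stronger inhibition and higher numbers for weaker inhibition), compound 1 reaches only the limit of > 4000 nM, so no number is known for it. Compound 2, `O=C1C=C(Nc2ccccc2)C(=O)c2c1nc1n2[C@H]2OC[C@@H](O)[C@H]2OC1`, has a plain anilino group at the same place; in this assay compound 2 also stops at the limit of > 4000 nM. Compound 3, `O=C1C=C(N2CCCCC2)C(=O)c2c1nc1n2[C@H]2OC[C@@H](O)[C@H]2OC1`, carries piperidin-1-yl instead; in this assay compound 3 gives the limit of > 8000 nM. The step that the two limits leave unreadable from compound 2 to compound 3 cannot be read because the limit of > 4000 nM in this assay, at which 2 of the 3 values shown sit, and the limit of > 8000 nM in this assay, at which 1 of the 3 values shown sits, cap both of its values. Compound 4, `O=C1C(Nc2cccc(F)c2)=CC(=O)c2c1nc1n2[C@H]2OC[C@@H](O)[C@H]2OC1`, differs from compound 1 by 3-fluorophenyl in place of 4-methylphenyl on an amine nitrogen. Going by the values given here, no measured step bears directly on this change, and the three values shown are all limits, so no size or direction of step can be expected beyond the scatter. Compound 4 is expected to sit near 6000 nM, most likely again as a limit, within a range from 2000 nM to 20000 nM. The expected step is a step that the limit leaves unreadable from compound 1 to compound 4.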

Compound 4, half-maximal inhibitory concentration: > 4000 nM
Compound 4 was reported as a limit; the forecaster's own chance of this, stated with the estimate: 75%; the middle value lies beyond the limit too.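

In this assay compound 1 and compound 4 both stop at a limit rather than a number, so no step between them can be read: the limit of > 4000 nM in this assay, at which 3 of the 4 values shown sit.

The compounds shown leave open how strongly any of them inhibits, and whether 3-fluorophenyl and 4-methylphenyl differ at all on the amine nitrogen.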